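The source may report more compounds than this note shows. Statements on the series, on what has been measured and on what is new or still open speak of the compounds shown alone.

Measured in an assay for inhibition of Tryptophan 2,3-dioxygenase (Homo sapiens), with stated times of 10 min and 60 min, tested at 100 uM; a higher number here means a stronger effect of the compound at the concentration tested, a lower number a weaker effect:
Compound 1 `O=C(O)CNc1cccc(CNc2cc(C(F)(F)F)cc3[nH]ncc23)c1` gives 65%.
Compound 2 `FC(F)(F)c1cc(NC[C@H]2CCCCN2)c2cn[nH]c2c1` gives 90%.
Compound 3 `CNC(=O)c1cccc(CNc2cc(C(F)(F)F)cc3[nH]ncc23)c1` gives 91%.

Compound 3 has the highest of the three numbers, though compound 2 sits within the scatter of it; only compound 1 lies clearly lower. Compound 4 `FC(F)(F)c1cc(NCc2cccc(Br)c2)c2cn[nH]c2c1` differs from compound 3 in one place: bromo in place of methylcarbamoyl on an aromatic carbon. Among the compounds with values here, no measured step swaps these two groups directly. Within the data shown here, the one step that bears on the same aromatic carbon is a number 26 percentage points higher from compound 1 to compound 3 (beyond the scatter), which shows that the group at this spot can move this assay beyond the scatter. Bromo carries no hydrogen-bond donor or acceptor, unlike both groups in that step, so that step does not fix the direction here; a modest drop is expected, a number 11 percentage points lower from compound 3 to compound 4 (beyond the scatter). Compound 4 is estimated at 80%, with a range from 55% to 95%.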

Compound 4, a percentage reported as inhibition, at one concentration (the size of the read-out at that concentration, not a potency): 84%
Estimate against measurement, compound 4: 4 percentage points below; the range from low to high includes it.
By their numbers in this assay, from the lowest: compound 1; then compounds 4, 2 and 3 (each within the scatter of the next).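

Bromo, with no hydrogen-bond donor or acceptor, does as well as methylcarbamoyl on this aromatic carbon in this assay: the step is a number 7 percentage points lower from compound 3 to compound 4 (within the scatter). Exchanging piperidin-2-yl for 3-bromophenyl also leaves no clear difference, a number 6 percentage points lower from compound 2 to compound 4 (within the scatter), whereas replacing (carboxymethyl)amino with bromo gives a number 19 percentage points higher from compound 1 to compound 4 (beyond the scatter), so among these three groups on this carbon only (carboxymethyl)amino gives a clearly different number. No measurement here explains these results. From the compounds shown here alone, whether a smaller group such as chloro, or a nitrile or methoxy, would fit this pattern stays open.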